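This account rests on a few compounds, and the source may have more. Where it says the series, first, only, none or still open, it means among the compounds named here.

Notes on the series. Among the measured compounds shown here, in an in vitro ADME assay on microsomes (Rattus norvegicus) for metabolic stability (on this read-out higher numbers stand for fast clearance and lower numbers for slow clearance), compound 1 `O=C(CN(C(=O)c1ccc(-c2ccccn2)cc1)C1CCCCC1)Nc1cc(F)cc(F)c1` gives 15.4 mL.min-1.g-1, the highest of the three numbers so far. Compound 2 `O=C(CN(C(=O)c1ccc(-c2ccccn2)cc1)C1CCOCC1)Nc1cc(F)cc(F)c1` gives 0.6 mL.min-1.g-1 in this assay, and compound 3 `COCC(C)N(CC(=O)Nc1cc(F)cc(F)c1)C(=O)c1ccc(-c2ccccn2)cc1` gives 4.2 mL.min-1.g-1 in this assay. Both steps away from compound 1 run the same way: a 26-fold lower number from compound 1 to compound 2 (1.41 log units; beyond the scatter), and a 3.7-fold lower number from compound 1 to compound 3 (0.56 log units; beyond the scatter). Between the two replacements, a 7.0-fold higher number from compound 2 to compound 3 (0.85 log units; beyond the scatter).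

Compound 4 `CCC(COC)N(CC(=O)Nc1cc(F)cc(F)c1)C(=O)c1ccc(-c2ccccn2)cc1` is the next member to be measured. Against compound 1 it differs in one place: 1-(methoxymethyl)propyl in place of cyclohexyl on an amide-type nitrogen. For the measured compounds named here, the nearest precedent is compound 3, where 1-(methoxymethyl)ethyl in place of cyclohexyl on the amide-type nitrogen gave a 3.7-fold lower number from compound 1 to compound 3 (0.56 log units; beyond the scatter); the group entering in compound 4 is a close relative of that chain and no ring enters, so the larger drop recorded in a 26-fold lower number from compound 1 to compound 2 (1.41 log units; beyond the scatter) is not taken as the reference. A modest lowering in this assay is therefore expected, of about the size seen for compound 3 in a 3.7-fold lower number from compound 1 to compound 3 (0.56 log units; beyond the scatter). The expected step is a 3.1-fold lower number from compound 1 to compound 4 (0.49 log units; beyond the scatter). For compound 4 the estimate in this assay is 5 mL.min-1.g-1, with a range from 2 mL.min-1.g-1 to 12 mL.min-1.g-1.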

Compound 4, intrinsic clearance in microsomes: 6.7 mL.min-1.g-1
For compound 4 the middle estimate is 1.3-fold (0.13 log units) below the measured one; the measured number falls inside the stated range.
By their numbers in this assay, from the lowest: compound 2; then compounds 3 and 4 (each within the scatter of the next); then compound 1.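

In this assay, one more methyl on the open chain at the amide-type nitrogen gives a step that stays within the scatter (a 1.6-fold higher number from compound 3 to compound 4 (0.20 log units; within the scatter)), so this extension does not separate compound 3 from compound 4. With cyclohexyl replaced by 1-(methoxymethyl)propyl, the heavy-atom count is unchanged, yet the number still falls (a 2.3-fold lower number from compound 1 to compound 4 (0.36 log units; beyond the scatter)), so at this position a lower number does not require a group with fewer heavy atoms than cyclohexyl. The open chain also remains well apart from oxan-4-yl (an 11-fold higher number from compound 2 to compound 4 (1.05 log units; beyond the scatter)).

No measurement shown gives a reason for any of these steps. Going by these compounds, whether a longer chain would stay level with compound 4, or a piperidin-4-yl amine in place of oxan-4-yl would stay near compound 2, remains open.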